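Swapping the Ring on the Aniline Nitrogen: Methyl to Methoxy

This account rests on a few compounds, and the source may have more. Where it says the series, first, only, none or still open, it means among the compounds named here.

Compound 1, `CC(C)c1ccc(-c2nc(SCc3cn(CC(=O)NC(=O)Nc4ccccn4)nn3)nc(Nc3ccccc3)c2C#N)cc1`: in a functional assay on ECa-109 cells (Homo sapiens) for inhibition, read by MTT assay, with a stated time of 72 h (on this read-out higher numbers stand for weaker inhibition and lower numbers for stronger inhibition), compound 1 gives > 64000 nM, which is a limit of the assay and not a number.
Compound 2, `Cc1cccc(Nc2nc(SCc3cn(CC(=O)NC(=O)Nc4ccccn4)nn3)nc(-c3ccc(C(C)C)cc3)c2C#N)c1`: in this assay compound 2 gives 7320 nM.

Compound 2 therefore holds the only actual number shown; the other value is a limit (the limit of > 64000 nM in this assay, at which 1 of the 2 values shown sits). For the measured compounds named here, the one measured step, an at least 8.7-fold lower number from compound 1 to compound 2 (0.94 log units; beyond the scatter), concerns the ring on the nitrogen of the shared core, where a methyl appears in place of hydrogen.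

Compound 3, `COc1ccccc1Nc1nc(SCc2cn(CC(=O)NC(=O)Nc3ccccn3)nn2)nc(-c2ccc(C(C)C)cc2)c1C#N`, changes that same ring again: 2-methoxyphenyl in place of 3-methylphenyl on a nitrogen on an aromatic ring. The methyl that accompanied the step from compound 1 is gone, and an oxygen-bearing group sits on the ring instead. Going by the values given here, the only measured step shows that decorating this ring can matter, but no step here tells what a methoxy does. A modest move in either direction is possible, and the estimate stays near compound 2 with a wide range. Compound 3 is expected to give 10000 nM, between 3000 nM and 40000 nM, meaning an expected step of a 1.4-fold higher number from compound 2 to compound 3 (0.14 log units; within the scatter).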

Compound 3, half-maximal inhibitory concentration: 8960 nM
For compound 3 the middle estimate is 1.1-fold (0.05 log units) above the measured one; the measured number falls inside the stated range.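

In this assay, replacing the ring on this nitrogen gives a 1.2-fold higher number from compound 2 to compound 3 (0.09 log units; within the scatter), so 3-methylphenyl and 2-methoxyphenyl cannot be told apart here, even though they differ in their atoms and only 2-methoxyphenyl carries a hydrogen-bond acceptor. For the compounds shown here, measured against the undecorated ring of compound 1, the methoxy gives an at least 7.1-fold lower number from compound 1 to compound 3 (0.85 log units; beyond the scatter), which means that a methyl is no longer the only group on this ring linked to a step beyond the scatter. The true size of that step remains unknown, as the result for compound 1 is a limit and not a number: the limit of > 64000 nM in this assay, at which 1 of the 3 values shown sits.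

The two decorated compounds differ both in the group and in where it sits on the ring, and these two changes cannot be separated with the compounds shown. From the compounds shown here alone, it also remains open whether a ring bearing an amine or a carboxylic acid on this nitrogen would give a number close to those of the methyl and methoxy compounds, or one that lies far from them.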